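Replacing thiophen-2-yl with 3-fluoropyridin-2-yl

This account rests on a few compounds, and the source may have more. Where it says the series, first, only, none or still open, it means among the compounds named here.

Of the compounds shown here, two have so far been tested in an ADME assay on 697 cells (Homo sapiens) for cytotoxicity, with a stated time of 48 h; a higher number here means a weaker inhibitor, a lower number a stronger inhibitor. Compound 1 `Cn1c(Sc2c(F)cc(C(=O)NO)cc2F)nnc1-c1cccs1` gives > 1000 nM, which is a limit of the assay and not a number. Compound 2 `O=C(NO)c1cc(F)c(Cc2nnc(-c3ccncc3)s2)c(F)c1` gives > 1000 nM, which is also a limit. The data so far come down to the limit of > 1000 nM in this assay, at which 2 of the 2 values shown sit, so compound 1 has a limit as its only standing and no exact value.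

Compound 3 `Cn1c(Sc2c(F)cc(C(=O)NO)cc2F)nnc1-c1ncccc1F` keeps the core of compound 1 but carries 3-fluoropyridin-2-yl in place of thiophen-2-yl on an aromatic carbon. Among the compounds with values here, no pair of measured compounds shows what a single change does in this assay, so any step can only be expected, not read from the data. Resting on compound 1, whose limit is > 1000 nM, the expectation is no large step in either direction, with a weak inhibitor again and quite possibly another limit. The estimated step is a step that the limit leaves unreadable from compound 1 to compound 3. For compound 3 the expected value is 2000 nM, with an estimated range of 800 nM to 6000 nM.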

Compound 3, half-maximal inhibitory concentration: > 1000 nM
Compound 3: only a limit was reported (the forecaster's own chance of this, stated with the estimate: 75%); the middle value lies beyond the limit too.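

In this assay compound 1 and compound 3 both give only a limit, and no step can be read for the change from thiophen-2-yl to 3-fluoropyridin-2-yl. The compounds shown leave open what exact value any of them has in this assay and what a single change does there: the limit of > 1000 nM in this assay, at which 3 of the 3 values shown sit.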